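A diol-bearing amide on the shared core

A few compounds are considered here, and "the series" means these few. Any claim that something is new, unique, unknown or untested is made for them only; others in the source may bear on it.

Compound 3 `CCC(C)C(NC(=O)c1ccc(C(CC)(CC)c2ccc(OCCC(O)(CC)CC)c(C)c2)n1CC)C(=O)OC` sits at a limit: in a functional assay on PC-3 cells (Homo sapiens) for antiproliferative activity, read by MTT assay, with a stated time of 48 h (on this read-out higher numbers stand for weaker inhibition and lower numbers for stronger inhibition), compound 3 gives > 50000 nM, which is a limit of the measurement and not a number. Compound 2 `C#CCCOC(=O)c1ccc(C(CC)(CC)c2ccc(OCCC(O)(CC)CC)c(C)c2)n1CC` is at a limit as well, giving > 50000 nM in this assay. Compound 1 `CCn1c(C(=O)NCCN)ccc1C(CC)(CC)c1ccc(OCCC(O)(CC)CC)c(C)c1` gives 2420 nM in this assay. The step of an at least 20-fold higher number from compound 1 to compound 3 (1.31 log units; beyond the scatter) was large, and an at least 20-fold higher number from compound 1 to compound 2 (1.31 log units; beyond the scatter) likewise; the step that the two limits leave unreadable from compound 2 to compound 3 cannot be read, since the limit of > 50000 nM in this assay, at which 2 of the 3 values shown sit, holds both compounds.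

Compound 4 `CCn1c(C(=O)NC(CO)CCO)ccc1C(CC)(CC)c1ccc(OCCC(O)(CC)CC)c(C)c1` differs from compound 3 in one place: a group of 6 heavy atoms (4 carbon, 2 oxygen; no ring) in place of a group of 9 heavy atoms (7 carbon, 2 oxygen; no ring), on an amide-type nitrogen. Within the data shown here, no measured step covers this exact exchange on the amide-type nitrogen. Among the measured compounds shown here, the only group on that nitrogen that gave a number is the one in compound 1, so the direction from compound 3 may well be downward, but the starting point is a limit and the size is uncertain. The expected step is an at least 2.5-fold lower number from compound 3 to compound 4 (0.39 log units; beyond the scatter). Compound 4 is therefore estimated at 20000 nM, with a range from 5000 nM to 60000 nM.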

Compound 4, half-maximal inhibitory concentration: 8760 nM
Beside the measured number, compound 4's estimate is 2.3-fold (0.36 log units) above it; low and high end bracket the measured number.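

With 3-hydroxy-1-(hydroxymethyl)propyl on the amide-type nitrogen, compound 4 gives a second group at this place that reads as a number in this assay, and this group holds no nitrogen, so a number here does not depend on the nitrogen of the 2-aminoethyl group in compound 1. The change gives an at least 5.7-fold lower number from compound 3 to compound 4 (0.75 log units; beyond the scatter) and, on the carbonyl carbon, an at least 5.7-fold lower number from compound 2 to compound 4 (0.75 log units; beyond the scatter), and both steps are only bounds, set by the limit that holds their starting compounds: the limit of > 50000 nM in this assay, at which 2 of the 4 values shown sit.

The 2-aminoethyl group still keeps the lower number, with a 3.6-fold higher number from compound 1 to compound 4 (0.56 log units; beyond the scatter).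

The compounds shown do not separate the effect of the amine in compound 1 from that of its chain. On these data alone, how a longer aminoalkyl chain or a carboxylic acid on this nitrogen would read stays open.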